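Replacing 2,6-dimethoxyphenyl with 2,4-dichlorophenyl in a growth-inhibition series

The source may hold more compounds than are shown below. What is called first, only, known or untested is meant among the compounds shown, and "the series" means these compounds.

Measured in a functional assay on NCI-H460 cells (Homo sapiens) for inhibition, read by sulforhodamine B assay, with a stated time of 48 h; on this read-out higher numbers stand for weaker inhibition of growth and lower numbers for stronger inhibition of growth
Compound 1 (`O=C(Cc1csc2nc(-c3ccc(Br)cc3)cn12)N/N=C/c1ccccc1`) gives 52500 nM
Compound 2 (`O=C(Cc1csc2nc(-c3ccc(Br)cc3)cn12)N/N=C/c1ccccc1O`) gives 15800 nM
Compound 3 (`COc1cccc(OC)c1/C=N/NC(=O)Cc1csc2nc(-c3ccc(Br)cc3)cn12`) gives only a limit (< 100000 nM)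

Compound 3 has no exact value on this scale, and its entry is a limit (< 100000 nM). Compound 4 (`O=C(Cc1csc2nc(-c3ccc(Br)cc3)cn12)N/N=C/c1ccc(Cl)cc1Cl`) departs from it by one change (2,4-dichlorophenyl in place of 2,6-dimethoxyphenyl on a carbon with a double bond to nitrogen): 2,4-dichlorophenyl in place of 2,6-dimethoxyphenyl on a carbon with a double bond to nitrogen.

Among the measured compounds shown here, two measured steps touch compound 3 but give no size (a step that the limit leaves unreadable from compound 1 to compound 3; a step that the limit leaves unreadable from compound 2 to compound 3). For the measured compounds named here, the only readable step is modest (a 3.3-fold lower number from compound 1 to compound 2 (0.52 log units; beyond the scatter)), and it concerns a hydroxy group, not chlorine, so it is a weak guide. Compound 4 is therefore expected to fall in the same broad region as compound 1 (52500 nM) in this assay. The number for compound 4 is expected to be lower than the limit of compound 3. The expected step is (a step that the limit leaves unreadable from compound 3 to compound 4), and its size stays uncertain. For compound 4 the estimated value is 30000 nM (expected range 9000 nM to 100000 nM).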

Compound 4, concentration for 50% growth inhibition: < 100000 nM
Compound 4 ended at the assay's limit; the forecaster's own chance of this, stated with the estimate: 25%; the middle value lies beyond the limit too.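

In this assay compound 4 gives only a limit, < 100000 nM. Among the compounds shown here, no step to compound 4 from compound 1, compound 2 or compound 3 can be read. The compounds shown leave open where compound 3 and compound 4 lie on this scale, and so whether 2,4-dichlorophenyl differs from 2,6-dimethoxyphenyl, phenyl or 2-hydroxyphenyl.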